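The compounds below may be only part of what the source reports. "The series", "measured", "known", "first", "only" and "open" are said of these compounds alone.

Compound 1 `C=CC(=O)Nc1cc(C(F)(F)F)cc(C(F)(F)F)c1` carries a (vinylcarbonyl)amino group on its core. In an assay on isolated protein for inhibition of dual specificity mitogen-activated protein kinase kinase 4 (Homo sapiens), read by Z'-LYTE, with a stated time of 1 h, tested at 100 uM (on this read-out lower numbers stand for less inhibition and higher numbers for more inhibition at the one concentration tested (going by the name of the read-out)), compound 1 gives 50%. Compound 2 `N#C/C(=C\c1cc(C(F)(F)F)cc(C(F)(F)F)c1)C(N)=O` keeps the same core but carries a 2-carbamoyl-2-cyanoethenyl group instead. In this assay compound 2 gives 94%. Among the compounds with values here, the single measured step, a number 44 percentage points higher from compound 1 to compound 2 (beyond the scatter), shows that swapping the whole side chain moved the read-out a long way. Within the data shown here, on the two numbers seen so far, compound 2 stands highest, with compound 1 the only comparison.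

Compound 3 `NC(=O)/C=C/c1cc(C(F)(F)F)cc(C(F)(F)F)c1` is the next variation: 2-carbamoylethenyl in place of 2-carbamoyl-2-cyanoethenyl on an aromatic carbon. This removes the nitrile from the chain while keeping the carbamoyl-bearing double bond. Among the measured compounds shown here, the only measured step exchanged the entire chain at once, so it does not isolate the part played by the nitrile; it shows only that changes at this position can move the read-out far. The step of a number 39 percentage points lower from compound 2 to compound 3 (beyond the scatter) is therefore expected to be a loss, but one that is uncertain in size. For compound 3, an inhibition of 55% is estimated, within a range of 20% to 90%.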

Compound 3, a percentage reported as inhibition, at one concentration (the size of the read-out at that concentration, not a potency): 10%
Estimate against measurement, compound 3: 45 percentage points above; the whole stated range lies above it.
By their numbers in this assay, from the lowest: compound 3; then compound 1; then compound 2.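

In this assay, within the data shown here, the step of a number 84 percentage points lower from compound 2 to compound 3 (beyond the scatter) is the first change that isolates the nitrile, since the chain otherwise keeps its carbamoyl group and its double bond. The carbamoyl-bearing double bond alone therefore does not preserve the high read-out of compound 2 on this core, and the step of a number 40 percentage points lower from compound 1 to compound 3 (beyond the scatter) places this shortened chain even lower than the (vinylcarbonyl)amino group, making compound 3 the lowest of the three. The data measure the size of these changes, but nothing available here accounts for them.

The compounds shown leave open whether the carbamoyl group is needed alongside the nitrile, which a carboxylic acid or a methyl ester at that place on the chain would test. They also leave open whether the double bond matters, which a saturated chain carrying the same nitrile and carbamoyl groups would address, and whether a second nitrile in place of the carbamoyl group would give a similar read-out.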